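The source may hold more compounds than are shown below. What is called first, only, known or untested is meant among the compounds shown, and "the series" means these compounds.

Of the compounds shown here, two have been measured in an assay on cells for inhibition of Palmitoleoyl-protein carboxylesterase NOTUM variant C330S (Homo sapiens), read by fluorescence, with a stated time of 40 min; a higher number here means a weaker inhibitor, a lower number a stronger inhibitor. Compound 1 `O=C(O)C1CCN(c2ccc(F)cc2)C1` gives 15000 nM in this assay, and compound 2 `CNC(=O)C1CCN(c2ccc(Cl)c(C(F)(F)F)c2)C1` gives 1300 nM in this assay, so compound 2 holds the lower of the two numbers. Compound 3 `CN1CN(C(=O)C2CCN(c3ccc(Cl)c(C(F)(F)F)c3)C2)CC1=O` has not yet been measured. Its change from compound 2 is a group of 7 heavy atoms (4 carbon, 2 nitrogen, 1 oxygen; one five-membered non-aromatic ring with 2 hetero atoms) in place of a group of 2 heavy atoms (1 carbon, 1 nitrogen; no ring), on a carbonyl carbon. Among the measured compounds shown here, no step between measured compounds resembles this change, so its size is open. The expected step is a 1.5-fold higher number from compound 2 to compound 3 (0.19 log units; within the scatter), a small move that may still fall within the usual scatter. Compound 3 is estimated at 2000 nM, with a range from 500 nM to 8000 nM.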

Compound 3, half-maximal inhibitory concentration: 1400 nM
Estimate against measurement, compound 3: 1.4-fold (0.15 log units) above, within the range that was stated.
By their numbers in this assay, from the lowest: compounds 2 and 3 (each within the scatter of the next); then compound 1.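

In this assay swapping methylamino on the carbonyl carbon for the five-membered non-aromatic ring group gives a 1.1-fold higher number from compound 2 to compound 3 (0.03 log units; within the scatter) and so leaves the two readings indistinguishable. This position can therefore carry a much larger group, one with no hydrogen-bond donor, without a change beyond the scatter, at least for this one ring. No measured evidence is at hand to explain this result. From the compounds shown here alone, whether a dimethylamino group or a piperidine ring on the same carbonyl carbon would read alike stays open.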